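Piperidine aryl swap on the benzoxazinone amide core

This account rests on a few compounds, and the source may have more. Where it says the series, first, only, none or still open, it means among the compounds named here.

Three measured compounds frame the series. Compound 1 `O=C1CSc2ccc(NC(=O)C3CCN(c4cc(F)c(F)c(F)c4)CC3)cc2N1` gives 1960 nM in a functional assay for antagonist activity at transient receptor potential cation channel subfamily V member 1 (Homo sapiens), read by FLIPR and calcium flux; on this read-out lower numbers stand for stronger inhibition and higher numbers for weaker inhibition. Compound 3 `O=C1COc2ccc(NC(=O)C3CCN(c4cccc(Br)c4)CC3)cc2N1` gives 330 nM in this assay. Compound 2 `O=C(Nc1ccc2cc[nH]c2c1)C1CCN(c2cccc(C(F)(F)F)c2)CC1`, which carries an indole in place of the fused bicyclic core, returns only a limit in this assay, namely > 9000 nM; this is a limit of the assay and not a number (the limit of > 9000 nM in this assay, at which 1 of the 3 values shown sits). Among the two numbers shown, compound 3 stands lowest, and the gap to compound 1 lies beyond the scatter.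

The next compound, compound 4 `O=C1COc2ccc(NC(=O)C3CCN(c4ccccc4C(F)(F)F)CC3)cc2N1`, keeps the core of compound 3 and changes only the aryl on the piperidine nitrogen: 2-(trifluoromethyl)phenyl in place of 3-bromophenyl on an amine nitrogen in a ring. Within the data shown here, no step between measured compounds isolates this change, so no measured step size is available for it; compound 2 carries a trifluoromethylphenyl but on a different core, and its limit says only that it was inactive at the top of the range tested.

For compound 4 the expectation is a weaker number than for compound 3, with the step of a 4.5-fold higher number from compound 3 to compound 4 (0.66 log units; beyond the scatter) expected to lie beyond the scatter. Compound 4 is estimated at 1500 nM in this assay, with a plausible range from 400 nM to 6000 nM.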

Compound 4, half-maximal inhibitory concentration: 380 nM
Compound 4: the middle estimate sits 3.9-fold (0.60 log units) above what was measured; the whole stated range lies above it.
By their numbers in this assay, from the lowest: compounds 3 and 4 (each within the scatter of the next); then compound 1. At a limit, above all of these: compound 2.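

In this assay, putting 2-(trifluoromethyl)phenyl in place of 3-bromophenyl on the amine nitrogen in a ring gives a 1.2-fold higher number from compound 3 to compound 4 (0.06 log units; within the scatter), so on the shared core these two aryl groups cannot be told apart at this position. Among these compounds, this is the first measured step that isolates a single change, and it shows that the position can take a quite different substituted phenyl without a readable shift in the number. Nothing measured here accounts for this outcome.

Still open is how the position responds to groups of another kind, such as a phenyl carrying a carboxylic acid or an amine, or a longer alkyl chain in place of the aryl; only substituted phenyl groups appear among the compounds shown. Also open is what a change of core alone does with the aryl held fixed, with compounds 1 and 2 each differing from compound 3 in more than one place and compound 2 standing only at a limit of the assay, not a number: the limit of > 9000 nM in this assay, at which 1 of the 4 values shown sits.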